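Pyrazin-2-yl in place of phenyl: working notes

The compounds below may be only part of what the source reports. "The series", "measured", "known", "first", "only" and "open" are said of these compounds alone.

compound 1 `O=C(Nc1c(O)cccc1-c1nc2c(C(=O)O)cccc2o1)c1cccc(Cl)c1`: 143000 nM
compound 2 `O=C(Nc1c(O)cccc1-c1nc2c(C(=O)O)cccc2o1)c1ccccc1`: > 240000 nM (a limit)

Both entries come from an ADME assay on L6 cells (Rattus norvegicus) for cytotoxicity; a higher number here means a weaker inhibitor, a lower number a stronger inhibitor. Compound 2 stands at the limit of > 240000 nM in this assay, at which 1 of the 2 values shown sits, so it has a limit and no number.

Compound 3 `O=C(Nc1c(O)cccc1-c1nc2c(C(=O)O)cccc2o1)c1cnccn1` carries pyrazin-2-yl in place of phenyl on a carbonyl carbon. Within the data shown here, the only measured step, an at least 1.6-fold higher number from compound 1 to compound 2 (0.22 log units; that floor lies within the scatter), is hydrogen in place of chloro, a different change, and it offers only a weak guide. No shift beyond the scatter is therefore expected in this assay, in either direction. The expected step is a number no higher from compound 2 to compound 3 (the limit leaves the size open). For compound 3 the estimate is 240000 nM, with an expected range of 120000 nM to 400000 nM.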

Compound 3, half-maximal inhibitory concentration: 94400 nM
The estimate for compound 3 lay 2.5-fold (0.41 log units) above the measured number, outside the stated range (below it).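

In this assay, among these compounds, a ring change on this carbonyl carbon moves the number clearly for the first time, as pyrazin-2-yl in place of phenyl gives an at least 2.5-fold lower number from compound 2 to compound 3 (0.40 log units; beyond the scatter). Compound 2 has a limit and not a number, so this step is only a floor: the limit of > 240000 nM in this assay, at which 1 of the 3 values shown sits. Pyrazin-2-yl and 3-chlorophenyl are not separated, with a 1.5-fold lower number from compound 1 to compound 3 (0.18 log units; within the scatter).

On these data alone, whether a pyridin-2-yl group, with a single ring nitrogen, would give a similar number on this carbonyl carbon remains open. So does the result for a saturated ring such as piperidin-1-yl.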